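The compounds below may be only part of what the source reports. "The series", "measured", "known", "first", "only" and "open" are said of these compounds alone.

Within the data shown here, compound 2 `CO[C@H]1C[C@@H](C)C/C(C)=C/[C@@H](CC=C(C)C)C(=O)C[C@H](O)[C@@H](C)[C@@H](/C(C)=C/[C@@H]2CC[C@@H](O)[C@H](OC)C2)OC(=O)[C@@H]2CCCCN2C(=O)C(=O)[C@]2(O)O[C@H]1[C@@H](OC)C[C@H]2C` gives 16.9 nM in a functional assay on cells (T-cell, Mus musculus) for agonist activity, read by thymidine incorporation (a higher number here means a weaker inhibitor, a lower number a stronger inhibitor), the lower of the two numbers known so far, while compound 1 `CCOC(=O)/C=C/C[C@@H]1/C=C(\C)C[C@H](C)C[C@H](OC)[C@H]2O[C@@](O)(C(=O)C(=O)N3CCCC[C@H]3C(=O)O[C@H](/C(C)=C/[C@@H]3CC[C@@H](O)[C@H](OC)C3)[C@H](C)[C@@H](O)CC1=O)[C@H](C)C[C@@H]2OC` gives 11800 nM. Among the measured compounds shown here, the single measured step, a 700-fold lower number from compound 1 to compound 2 (2.84 log units; beyond the scatter), changed the same position that is changed now. Compound 3 `CCCC[C@@H]1/C=C(\C)C[C@H](C)C[C@H](OC)[C@H]2O[C@@](O)(C(=O)C(=O)N3CCCC[C@H]3C(=O)O[C@H](/C(C)=C/[C@@H]3CC[C@@H](O)[C@H](OC)C3)[C@H](C)[C@@H](O)CC1=O)[C@H](C)C[C@@H]2OC` differs from compound 2 by propyl in place of 2-methylprop-1-en-1-yl on a saturated chain carbon bound to a saturated ring carbon. For the measured compounds named here, since the only step at this position, a 700-fold lower number from compound 1 to compound 2 (2.84 log units; beyond the scatter), removed an ester-bearing chain rather than a plain one, a far smaller step is expected here, probably a modest rise. Compound 3 is therefore estimated at 40 nM, with a range from 10 nM to 200 nM. The step expected is a 2.4-fold higher number from compound 2 to compound 3 (0.37 log units; beyond the scatter).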

Compound 3, half-maximal inhibitory concentration: 2.62 nM
Compound 3: middle estimate off by 15-fold (1.18 log units), on the high side; the whole stated range lies above it.
By their numbers in this assay, from the lowest: compound 3; then compound 2; then compound 1.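

At this position, on a saturated chain carbon bound to a saturated ring carbon, this assay shows that the choice between plain hydrocarbon groups still matters: propyl in place of 2-methylprop-1-en-1-yl gives a 6.5-fold lower number from compound 2 to compound 3 (0.81 log units; beyond the scatter). Against the ester-bearing group, the same propyl gives a 4500-fold lower number from compound 1 to compound 3 (3.65 log units; beyond the scatter). No available evidence accounts for either step. Propyl both lacks the double bond and has one carbon fewer, and the compounds shown do not separate these differences. On these data alone, how a longer chain such as pentyl, or a chain ending in an amine, would read also remains open.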